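A few compounds are considered here, and "the series" means these few. Any claim that something is new, unique, unknown or untested is made for them only; others in the source may bear on it.

Compound 1 `COc1cc(C(=O)c2cn(-c3cccc(N)c3)cc2-c2ccccc2F)cc(OC)c1OC`: 17 nM
Compound 2 `COc1cc(C(=O)c2cn(-c3cccc(N)c3)cc2-c2ccccc2Cl)cc(OC)c1OC`: 40 nM

Both were tested in a functional assay on MCF7 cells (Homo sapiens) for cytotoxicity, read by MTT assay, with a stated time of 96 h (on this read-out higher numbers stand for weaker inhibition and lower numbers for stronger inhibition), where compound 2, at 40 nM, has the higher of the two numbers. Compound 3 `COc1cc(C(=O)c2cn(-c3cccc(N)c3)cc2-c2ccccc2[N+](=O)[O-])cc(OC)c1OC` differs from it by nitro in place of chloro on an aromatic carbon, with nitro in place of chloro on an aromatic carbon, ortho to a large group. Going by the values given here, the only measured step at this place is a 2.4-fold higher number from compound 1 to compound 2 (0.37 log units; beyond the scatter), a modest one beyond the scatter, so a similarly modest change is expected in this assay, leaning weakly upward. The expected change is a 1.4-fold higher number from compound 2 to compound 3 (0.14 log units; within the scatter). For compound 3 the estimated value is 55 nM, with an expected range of 15 nM to 200 nM.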

Compound 3, half-maximal inhibitory concentration: 14 nM
For compound 3 the middle estimate is 3.9-fold (0.59 log units) above the measured one; measured number below the stated range.
By their numbers in this assay, from the lowest: compounds 3 and 1 (each within the scatter of the next); then compound 2.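

In this assay the chloro compound proves the outlier at this position, with a 2.9-fold lower number from compound 2 to compound 3 (0.46 log units; beyond the scatter) when nitro replaces chloro on the aromatic carbon. Nitro in place of fluoro gives a 1.2-fold lower number from compound 1 to compound 3 (0.08 log units; within the scatter) and so no change that can be told from the scatter, which shows that this position accepts a nitro group as well as a fluoro group. Nothing measured here bears on why the chloro compound stands apart.

From the compounds shown here alone, whether an amine or a carboxylic acid in this place would match compound 3 remains open.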